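The compounds below may be only part of what the source reports. "The series", "measured", "known", "first", "only" and "open" are said of these compounds alone.

For the measured compounds named here, compound 3 `Cc1cccc(-c2nnc(CSc3nnc(/N=C/c4ccccc4O)s3)o2)c1` gives the highest of the three numbers measured so far in a functional assay on A549 cells (Homo sapiens) for inhibition, read by CCK-8 assay (a higher number here means a weaker inhibitor, a lower number a stronger inhibitor), a half-maximal inhibitory concentration of 24300 nM. Compound 1 `Oc1ccccc1/C=N/c1nnc(SCc2nnc(-c3ccccc3Br)o2)s1` gives 7150 nM and compound 2 `Oc1ccccc1/C=N/c1nnc(SCc2nnc(-c3ccc(Br)cc3)o2)s1` gives 20000 nM. The step under consideration leads to compound 4 `COc1ccc(-c2nnc(CSc3nnc(/N=C/c4ccccc4O)s3)o2)cc1`, where (4-methoxyphenyl in place of 3-methylphenyl on an aromatic carbon). Going by the values given here, two measured steps bear on substituent changes on this phenyl ring: a 3.4-fold higher number from compound 1 to compound 3 (0.53 log units; beyond the scatter), and a 1.2-fold higher number from compound 2 to compound 3 (0.08 log units; within the scatter). Moving the bromine also gave a 2.8-fold higher number from compound 1 to compound 2 (0.45 log units; beyond the scatter). Since the exchange between compound 2 and compound 3 stayed within the scatter, a step of similar character is expected here, a 1.0-fold higher number from compound 3 to compound 4 (0.01 log units; within the scatter), with no change beyond the scatter. Compound 4 is therefore estimated at 25000 nM, with a range from 9000 nM to 70000 nM.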

Compound 4, half-maximal inhibitory concentration: 20300 nM
Beside the measured number, compound 4's estimate is 1.2-fold (0.09 log units) above it; measured number inside the range.
By their numbers in this assay, from the lowest: compound 1; then compounds 2, 4 and 3 (each within the scatter of the next).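

In this assay, replacing 3-methylphenyl with 4-methoxyphenyl gives a 1.2-fold lower number from compound 3 to compound 4 (0.08 log units; within the scatter), and exchanging the bromo for methoxy gives a 1.0-fold higher number from compound 2 to compound 4 (0.01 log units; within the scatter), so the hydrogen-bond acceptor that enters with the methoxy brings no change beyond the scatter. Against the 2-bromophenyl group the new compound gives a 2.8-fold higher number from compound 1 to compound 4 (0.45 log units; beyond the scatter), leaving compound 1 as the only one of the four set apart. No evidence here explains these results. As far as these compounds go, it remains open whether an amine or a carboxylic acid on this phenyl ring would change the number beyond the scatter.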